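The compounds below may be only part of what the source reports. "The series", "measured", "known", "first", "only" and "open" are said of these compounds alone.

Compound 3 `COc1cc(-c2ccnc(N)n2)cc2[nH]nc(N)c12` carries a methyl on an oxygen on an aromatic ring, and in a physicochemical assay for solubility, read by LC-MS, in phosphate buffer, measured as kinetic solubility, with a stated time of 24 h, at 25 degrees C, at pH 7.4 (a higher number here means a more soluble compound, a lower number a less soluble compound), compound 3 gives > 100000 nM, which is a limit of the assay rather than a number, so its true place is not known (the limit of > 100000 nM in this assay, at which 1 of the 3 values shown sits). Two close relatives have readable numbers: compound 1 `Nc1nccc(-c2cc(OC3CCOC3)c3c(N)n[nH]c3c2)n1` gives 751000 nM in this assay, and compound 2 `Nc1nccc(-c2cc(OC3COC3)c3c(N)n[nH]c3c2)n1` gives 383000 nM. For the measured compounds named here, the only readable step among them, a 2.0-fold lower number from compound 1 to compound 2 (0.29 log units; within the scatter), concerns a change between two small oxygen-containing rings. The steps into compound 3, a step that the limit leaves unreadable from compound 1 to compound 3 and a step that the limit leaves unreadable from compound 2 to compound 3, offer no size. Compound 4 `Nc1nccc(-c2cc(Oc3ccccc3)c3c(N)n[nH]c3c2)n1` is the next target, differing from compound 3 in one place: phenyl in place of methyl on an oxygen on an aromatic ring. Going by the values given here, no measured step in this set swaps a methyl for a phenyl, so the expectation rests on the change itself rather than on a measured precedent. A lower number than the relatives with small rings is expected, and the step of an at least 1.6-fold lower number from compound 3 to compound 4 (0.22 log units; that floor lies within the scatter) is an estimate only. For compound 4 the expected value in this assay is 60000 nM, within a range from 10000 nM to 300000 nM.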

Compound 4, solubility: 117000 nM
For compound 4 the middle estimate is 2.0-fold (0.29 log units) below the measured one; the measured number falls inside the stated range.
By their numbers in this assay, from the lowest: compound 4; then compounds 2 and 1 (each within the scatter of the next).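

In this assay, replacing a small oxygen-containing ring on this oxygen with phenyl gives steps that clear the scatter: a 3.3-fold lower number from compound 2 to compound 4 (0.52 log units; beyond the scatter), and a 6.4-fold lower number from compound 1 to compound 4 (0.81 log units; beyond the scatter). The earlier swap between oxolan-3-yl and oxetan-3-yl stayed within the scatter, so this position can show a readable change when the incoming group is an aromatic ring of carbon only. The step from methoxy to phenoxy cannot be read, nor can any other step into compound 3, because the value of compound 3 is a limit: the limit of > 100000 nM in this assay, at which 1 of the 4 values shown sits.

The compounds shown leave open whether these steps follow from the aromatic ring or from the loss of the ring oxygen, which a cyclohexyl group on the same oxygen would help to separate. Going by these compounds, how a phenyl carrying an amine or a carboxylic acid would read in this assay also stays open.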